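This account rests on a few compounds, and the source may have more. Where it says the series, first, only, none or still open, it means among the compounds named here.

Measured so far:
compound 1, `Cc1ccc2nc(/N=C3\C(=O)N(CN4CCCCC4)c4ccccc43)sc2c1`: 34900 nM
compound 2, `Cc1ccc2nc(/N=C3\C(=O)N(CN(C)C)c4cccc(Br)c43)sc2c1`: 74800 nM

Both numbers come from an ADME assay on 184B5 cells (Homo sapiens) for cytotoxicity, read by sulforhodamine B assay, with a stated time of 48 h; on this read-out lower numbers stand for stronger inhibition of growth and higher numbers for weaker inhibition of growth. Within the data shown here, compound 2 stands at the higher of the two numbers in this assay; its only neighbour, compound 1, gives a number lower by a margin beyond the scatter. The two structures differ in more than one place, so what separates them cannot be tied to a single change.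

The next compound, compound 3 `Cc1ccc2nc(/N=C3\C(=O)N(CN(C)C)c4ccccc43)sc2c1`, has yet to be measured in this assay. Relative to compound 2 it differs in one place: hydrogen in place of bromo on an aromatic carbon. Among the measured compounds shown here, no measured pair shows this change on its own, so the data here give no direct reading of its size. Compound 1, which also carries no bromo, sits lower than compound 2, but its amine part differs as well, so it is only a loose pointer. For compound 3 the expected step in this assay is a 1.7-fold lower number from compound 2 to compound 3 (0.22 log units; within the scatter), modest and towards a lower number, without confidence that it clears the scatter. The estimate for compound 3 is 45000 nM, with a range from 15000 nM to 130000 nM.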

Compound 3, concentration for 50% growth inhibition: 15600 nM
For compound 3 the middle estimate is 2.9-fold (0.46 log units) above the measured one; measured number inside the range.
By their numbers in this assay, from the lowest: compound 3; then compound 1; then compound 2.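

In this assay, the bromo on the aromatic carbon can now be read on its own: with the dimethylamino part held constant, hydrogen in place of bromo gives a 4.8-fold lower number from compound 2 to compound 3 (0.68 log units; beyond the scatter), a step beyond the scatter, so this position of the six-membered aromatic ring of carbon does respond to the change. In the absence of bromo, the amine part can also be read on its own, since dimethylamino in place of piperidin-1-yl on the saturated chain carbon gives a 2.2-fold lower number from compound 1 to compound 3 (0.35 log units; beyond the scatter), likewise beyond the scatter. Compound 3 therefore carries the lowest number of the three in this assay, with both single-place steps to it beyond the scatter, but no available measurement explains either step.

As far as these compounds go, it remains open whether chloro, fluoro or methoxy on the same aromatic carbon would track with bromo or with hydrogen. The compounds shown also leave open whether the bromo step holds when piperidin-1-yl replaces dimethylamino, and how a morpholin-4-yl group on the saturated chain carbon would compare with these two amines.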